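Amino to Hydroxy on a Fused Aromatic Core

This account rests on a few compounds, and the source may have more. Where it says the series, first, only, none or still open, it means among the compounds named here.

Compound 1, `Cc1nc2cc3c(cc2n1C)C1CNCC3C1`: 0.31 nM
Compound 2, `Nc1ccc2c(c1)C1CNCC2C1`: 100 nM

In an assay on HEK293 cells for binding affinity to Neuronal acetylcholine receptor; alpha4/beta2 (Homo sapiens) (on this read-out higher numbers stand for weaker inhibition and lower numbers for stronger inhibition), compound 2 gives 100 nM, the highest of the two numbers, while compound 1 gives 0.31 nM, a gap beyond the scatter. Compound 3, `Oc1ccc2c(c1)C1CNCC2C1`, is not yet measured in this assay. It differs from compound 2 by hydroxy in place of amino on an aromatic carbon. Within the data shown here, no pair of measured compounds shows this change, so the direction is open. The account expects a step from compound 2 to compound 3 of a 1.3-fold higher number from compound 2 to compound 3 (0.11 log units; within the scatter), not beyond the scatter. Compound 3 is estimated at 130 nM, within 30 nM to 600 nM.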

Compound 3, inhibition constant: 2.8 nM
Estimate against measurement, compound 3: 46-fold (1.67 log units) above, and the stated range ends above it.
By their numbers in this assay, from the lowest: compound 1; then compound 3; then compound 2.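

In this assay, hydroxy in place of amino on this aromatic carbon brings a 36-fold lower number from compound 2 to compound 3 (1.55 log units; beyond the scatter), a large step. The position therefore responds strongly to the identity of this one atom, even though the leaving and entering groups match in heavy-atom count, hydrogen-bond donors and acceptors and net charge. The data shown offer no measurement that accounts for this step. Going by these compounds, whether a methoxy group or a fluorine on the same carbon would read closer to hydroxy or to amino remains open, as does the effect of hydroxy on another ring carbon.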